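Working notes on a phenyl substituent change

A few compounds are considered here, and "the series" means these few. Any claim that something is new, unique, unknown or untested is made for them only; others in the source may bear on it.

Measured so far:
compound 1, `CC(C)c1ccc(Nc2ccc3c(OCCCN4CCN(C)CC4)cccc3n2)cc1`: 2850 nM
compound 2, `CN1CCN(CCCOc2cccc3nc(Nc4cc(Cl)cc(Cl)c4)ccc23)CC1`: "not determined" (no result reported)

Compound 1 is the compound `CC(C)c1ccc(Nc2ccc3c(OCCCN4CCN(C)CC4)cccc3n2)cc1`. Going by the values given here, in a functional assay on SR cells (Homo sapiens) for inhibition, read by sulforhodamine B assay, with a stated time of 48 h (on this read-out higher numbers stand for weaker inhibition of growth and lower numbers for stronger inhibition of growth), compound 1 gives 2850 nM, and this is the only number in hand for the series. Compound 2, `CN1CCN(CCCOc2cccc3nc(Nc4cc(Cl)cc(Cl)c4)ccc23)CC1`, gives "not determined" (no result reported) in this assay, so it adds nothing to compare against. Among the compounds with values here, with a single number there is no step between measured compounds and no measured direction to lean on.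

Compound 3, `CN1CCN(CCCOc2cccc3nc(Nc4cccc(Cl)c4)ccc23)CC1`, differs from compound 1 in one place: 3-chlorophenyl in place of 4-isopropylphenyl on a nitrogen on an aromatic ring. The change swaps one six-membered aromatic ring of carbon only for another, with no donors or acceptors gained or lost and no change in net charge. Nothing measured in the series shows how this assay responds to such a swap. The expectation is therefore for no step beyond the usual scatter, a 1.1-fold higher number from compound 1 to compound 3 (0.02 log units; within the scatter), rather than a clear gain or loss. Compound 3 is estimated at 3000 nM in this assay, with a range from 700 nM to 13000 nM kept wide for lack of any anchoring step.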

Compound 3, concentration for 50% growth inhibition: 2200 nM
Compound 3: middle estimate off by 1.4-fold (0.13 log units), on the high side; the range from low to high includes it.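

In this assay, going by these compounds alone, the exchange of 4-isopropylphenyl for 3-chlorophenyl on a nitrogen on an aromatic ring gives a 1.3-fold lower number from compound 1 to compound 3 (0.11 log units; within the scatter) and so provides the first measured step at this position, one that does not separate the two compounds. The exchange removes 9 heavy atoms, all carbon, and brings in 7 heavy atoms, one of them chlorine, yet this single pair shows no difference in the read-out beyond the usual scatter. No available evidence bears on the origin of this result.

The compounds shown leave open whether any change at this position can produce a step beyond the scatter, since the only comparison so far is between two phenyl groups carrying an isopropyl group and a chlorine, neither with a hydrogen-bond donor or acceptor. A phenyl ring bearing an amine or a carboxylic acid, or a longer alkyl chain in place of the isopropyl group, would test this position with a group not yet among the compounds.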